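Swapping Phenyl for Furan in a Cytotoxicity Series

The source may hold more compounds than are shown below. What is called first, only, known or untested is meant among the compounds shown, and "the series" means these compounds.

Measured compounds:
compound 1 `Oc1ccc(-c2cc(-c3ccccc3)nc(-c3ccccc3Cl)c2)cc1`: 2800 nM
compound 2 `Oc1cccc(-c2cc(-c3ccncc3)nc(-c3cccc(Cl)c3)c2)c1`: "not determined" (no result reported)

In a functional assay on DU-145 cells (Homo sapiens) for cytotoxicity, read by CCK-8 assay and cell counting, with a stated time of 2 days (a higher number here means a weaker inhibitor, a lower number a stronger inhibitor), compound 1 gives 2800 nM. Compound 2 gives "not determined" (no result reported) in this assay, so compound 1 carries the only number shown and stands alone as the reference point. Compound 3 `Oc1ccc(-c2cc(-c3ccco3)nc(-c3ccccc3Cl)c2)cc1` differs from compound 1 in one place: furan-2-yl in place of phenyl on an aromatic carbon. Among the measured compounds shown here, no measured pair shows such a swap, so the step from compound 1 to compound 3 is expected to stay within the scatter, a 1.1-fold higher number from compound 1 to compound 3 (0.03 log units; within the scatter). Compound 3 is estimated at 3000 nM, within 1200 nM to 8000 nM.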

Compound 3, half-maximal inhibitory concentration: 5300 nM
Beside the measured number, compound 3's estimate is 1.8-fold (0.25 log units) below it; the measured number falls inside the stated range.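

In this assay, putting furan-2-yl in place of phenyl next to the ring nitrogen gives a 1.9-fold higher number from compound 1 to compound 3 (0.28 log units; within the scatter). Compound 1 alone could not show this: the position accepts a five-membered aromatic ring with a hetero atom as well as a six-membered carbon ring, with no difference that can be told from ordinary scatter. Nothing measured here accounts for this result. Both groups compared at this position are aromatic rings. On these data alone, how an amine or a carboxylic acid would read there remains open.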